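Moving the chlorine on a diaryl pyridine core

The compounds below may be only part of what the source reports. "The series", "measured", "known", "first", "only" and "open" are said of these compounds alone.

Measured compounds:
compound 1 `Oc1cccc(-c2cc(-c3ccc(Cl)cc3)nc(-c3cccs3)c2)c1`: 11600 nM
compound 2 `Oc1cccc(-c2cc(-c3ccc(Cl)cc3)nc(-c3cccnc3)c2)c1`: 26800 nM

In a functional assay on DU-145 cells (Homo sapiens) for cytotoxicity, read by CCK-8 assay and cell counting, with a stated time of 2 days (on this read-out higher numbers stand for weaker inhibition and lower numbers for stronger inhibition), compound 1 gives the lowest of the two numbers, with compound 2 the nearest, a step of a 2.3-fold higher number from compound 1 to compound 2 (0.36 log units; beyond the scatter). Compound 3 `Oc1cccc(-c2cc(-c3cccs3)nc(-c3ccccc3Cl)c2)c1` differs from compound 1 by 2-chlorophenyl in place of 4-chlorophenyl on an aromatic carbon. Going by the values given here, no measured step touches this change; the only step recorded concerns a different ring, so it offers no guide for this pair. Compound 3 is therefore expected to lie near compound 1, with no step beyond the scatter, a 1.0-fold higher number from compound 1 to compound 3 (0.01 log units; within the scatter). The estimate for compound 3 is 12000 nM, within 4500 nM to 32000 nM.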

Compound 3, half-maximal inhibitory concentration: 1700 nM
For compound 3 the middle estimate is 7.1-fold (0.85 log units) above the measured one, and the stated range ends above it.
By their numbers in this assay, from the lowest: compound 3; then compound 1; then compound 2.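

In this assay, replacing 4-chlorophenyl with 2-chlorophenyl next to the ring nitrogen gives a 6.8-fold lower number from compound 1 to compound 3 (0.83 log units; beyond the scatter) and shows that the number responds to where the chlorine sits, though both groups hold the same atoms. The earlier step, pyridin-3-yl in place of thiophen-2-yl, concerned a different ring and showed nothing about this group. No evidence here accounts for the change. The compounds shown leave open how 3-chlorophenyl would compare. They also leave open whether a methoxy group or an amine could replace the chlorine of 2-chlorophenyl and keep the lower number.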